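Bromo for Chloro on the Anilide Ring of Compound 3

This account rests on a few compounds, and the source may have more. Where it says the series, first, only, none or still open, it means among the compounds named here.

The series shares one core, a hydrazide of a pyridine carboxylic acid joined to an anilide. Compound 1 `C/C(=N\NC(=O)c1ccncc1)C(=O)Nc1ccc(F)cc1` carries a 4-fluorophenyl group. In an ADME assay on HepG2 cells (Homo sapiens) for cytotoxicity, read by MTT assay (on this read-out lower numbers stand for stronger inhibition and higher numbers for weaker inhibition), compound 1 gives a limit of > 50000 nM. Compound 2 `C/C(=N\NC(=O)c1ccncc1)C(=O)Nc1cccc(Cl)c1` carries a 3-chlorophenyl group, and in this assay compound 2 also gives a limit of > 50000 nM. Compound 3 `C/C(=N\NC(=O)c1ccncc1)C(=O)Nc1ccc(Cl)cc1` carries a 4-chlorophenyl group, and in this assay compound 3 gives a limit of > 50000 nM. The steps a step that the two limits leave unreadable from compound 1 to compound 2, a step that the two limits leave unreadable from compound 1 to compound 3 and a step that the two limits leave unreadable from compound 2 to compound 3 therefore cannot be read in size, since (the limit of > 50000 nM in this assay, at which 3 of the 3 values shown sit). Compound 3 thus stands at the same limit as every other value shown.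

Compound 4 `C/C(=N\NC(=O)c1ccncc1)C(=O)Nc1ccc(Br)cc1` differs from compound 3 by bromo in place of chloro on an aromatic carbon. Within the data shown here, no measured step resolves a change of this kind, so no direction can be read for the step in this assay. Compound 4 is expected to remain at the same limit, an expected step that the limit leaves unreadable from compound 3 to compound 4. The estimate for compound 4 is 60000 nM, from 30000 nM to 150000 nM.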

Compound 4, half-maximal inhibitory concentration: > 50000 nM
Compound 4: no number, only a limit; the forecaster's own chance of this, stated with the estimate: 85%; the middle value is on the limit's open side.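

Compound 4 also gives only a limit in this assay, so its steps from compound 1, compound 2 and compound 3 cannot be read in size: the limit of > 50000 nM in this assay, at which 4 of the 4 values shown sit. The compounds shown leave open at what concentration any of them would reach half-maximal inhibition, and whether their anilide groups differ at all.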